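Carboxyphenyl in place of methylphenyl on the urea nitrogen

The source may report more compounds than this note shows. Statements on the series, on what has been measured and on what is new or still open speak of the compounds shown alone.

In an assay for inhibition of Type-2 angiotensin II receptor (Rattus norvegicus) (a higher number here means a weaker inhibitor, a lower number a stronger inhibitor), compound 3 `CCCCCN(CCCCC)C(=O)N1CCN(C(=O)N(c2ccccc2)c2cccc(C)c2)[C@H](C(=O)O)C1` gives 0.7 nM, the strongest of the three measured compounds. Compound 1 `CCCCCN(CCCCC)C(=O)N1CCN(C(=O)N(c2ccccc2)c2ccccc2)C(C(=O)O)C1` gives 1.7 nM in this assay, a gap beyond the usual scatter. Compound 2 `CCCCCN(CCCCC)C(=O)N1CCN(C(=O)N(c2ccccc2)c2ccccc2)C[C@H]1C(=O)O` gives 23 nM in this assay, the weakest of the three. Among the measured compounds shown here, no single-point steps between the measured compounds exist, so the bearing of each feature on this assay is not separated out.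

Compound 4 `CCCCCN(CCCCC)C(=O)N1CCN(C(=O)N(c2ccccc2)c2ccc(C(=O)O)cc2)[C@H](C(=O)O)C1` differs from compound 3 in one place: 4-carboxyphenyl in place of 3-methylphenyl on an amide-type nitrogen whose other neighbours are an aromatic carbon and a carbonyl carbon. Nothing measured here shows what this exchange does, so a moderate loss of potency is expected, though it may stay within the scatter. Compound 4 is estimated at 5 nM in this assay, within 1 nM to 30 nM. The expected step from compound 3 to compound 4 is a 7.1-fold higher number from compound 3 to compound 4 (0.85 log units; beyond the scatter).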

Compound 4, half-maximal inhibitory concentration: 180 nM
Compound 4: middle estimate off by 36-fold (1.56 log units), on the low side; the measured number lies above the stated range.
By their numbers in this assay, from the lowest: compound 3; then compound 1; then compound 2; then compound 4.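

In this assay, putting 4-carboxyphenyl in place of 3-methylphenyl on an amide-type nitrogen whose other neighbours are an aromatic carbon and a carbonyl carbon brings a 260-fold higher number from compound 3 to compound 4 (2.41 log units; beyond the scatter), a large step beyond the scatter. This is the first single-place step among these compounds, and it shows that the number in this assay depends strongly on which substituted phenyl group stands on this nitrogen. No measurement at hand bears on the reason for a step of this size.

The step changes both the group on the phenyl ring and where it sits, so the compounds shown do not separate these two changes; 4-methylphenyl and 3-carboxyphenyl would each isolate one of them. From the compounds shown here alone, it also remains open whether a methyl ester or a primary amide in place of the carboxylic acid at the same place would give a similar step.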